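Butyl in Place of sec-Butyl on the Shared Core

The compounds below may be only part of what the source reports. "The series", "measured", "known", "first", "only" and "open" are said of these compounds alone.

Measured compounds:
compound 1, `CCC(C)NC(=O)NCCCOc1cccc(CN2CCCCC2)c1`, gives 95.5 nM in an assay on isolated protein for inhibition of histamine H2 receptor (Cavia porcellus); a lower number here means tighter binding, a higher number weaker binding
compound 2, `O=C(NCCCOc1cccc(CN2CCCCC2)c1)NCc1ccccc1`, gives 347 nM in this assay
compound 3, `CNC(=O)NCCCOc1cccc(CN2CCCCC2)c1`, gives 155 nM in this assay

Compound 1 has the lowest number of the three. Its nearest neighbour is compound 3, with a step of a 1.6-fold higher number from compound 1 to compound 3 (0.21 log units; within the scatter) that lies within the scatter, while compound 2 is furthest, with a 3.6-fold higher number from compound 1 to compound 2 (0.56 log units; beyond the scatter). Compound 4, `CCCCNC(=O)NCCCOc1cccc(CN2CCCCC2)c1`, differs from compound 1 in one place: butyl in place of sec-butyl on an amide-type nitrogen. Within the data shown here, no measured step exchanges one chain for another of the same size; the closest guides are a 1.6-fold higher number from compound 1 to compound 3 (0.21 log units; within the scatter), where a much shorter chain changes little, and a 3.6-fold higher number from compound 1 to compound 2 (0.56 log units; beyond the scatter), where a ring enters and the number rises. Butyl has the same atoms as sec-butyl, joined differently, and brings no ring. The step to compound 4 is therefore expected to be small, a 1.1-fold lower number from compound 1 to compound 4 (0.05 log units; within the scatter), within the scatter and in no settled direction. Compound 4 is estimated at 85 nM, with a range from 40 nM to 200 nM.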

Compound 4, dissociation constant: 81.3 nM
Compound 4: middle estimate off by 1.0-fold (0.02 log units), on the high side, within the range that was stated.
By their numbers in this assay, from the lowest: compounds 4, 1 and 3 (each within the scatter of the next); then compound 2.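

Joining the same atoms as butyl rather than sec-butyl on the amide-type nitrogen gives no change that can be told from the scatter in this assay, with a 1.2-fold lower number from compound 1 to compound 4 (0.07 log units; within the scatter), so branching in this chain makes no visible difference for this pair. The step from the methyl group also stays within the scatter, with a 1.9-fold lower number from compound 3 to compound 4 (0.28 log units; within the scatter), so compounds 1, 3 and 4 cannot be separated, even though their chains differ in length and shape. With a 4.3-fold lower number from compound 2 to compound 4 (0.63 log units; beyond the scatter), compound 2, whose benzyl group brings a ring, now stands apart from all three, its steps to each lying beyond the scatter.

Nothing available explains why these chains read alike. Still open, going by these compounds, is whether a longer chain such as hexyl would stay level with butyl, and whether an amine or a carboxylic acid at the end of the chain would shift the number.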